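Chloro for fluoro on the benzyl ring of compound 2

The compounds below may be only part of what the source reports. "The series", "measured", "known", "first", "only" and "open" are said of these compounds alone.

Compound 2 `NC(=O)N1CCN(C(=S)SCc2cn(Cc3ccc(F)cc3)nn2)CC1` gives 62700 nM in a functional assay on EC9706 cells (Homo sapiens) for cytotoxicity, read by MTT assay, with a stated time of 72 h (a lower number here means a stronger inhibitor, a higher number a weaker inhibitor), the highest of the three numbers measured. Compound 1 `NC(=O)N1CCN(C(=S)SCc2cn(Cc3ccccc3F)nn2)CC1` gives 43100 nM, and compound 3 `CCN(C)C(=O)N1CCN(C(=S)SCc2cn(Cc3ccc(F)cc3)nn2)CC1` gives 14300 nM. The step of a 1.5-fold higher number from compound 1 to compound 2 (0.16 log units; within the scatter) concerned the fluorophenyl group, while the step of a 4.4-fold lower number from compound 2 to compound 3 (0.64 log units; beyond the scatter) concerned the substituent on the carbonyl carbon. Compound 4 `NC(=O)N1CCN(C(=S)SCc2cn(Cc3ccc(Cl)cc3)nn2)CC1` differs from compound 2 by chloro in place of fluoro on an aromatic carbon. Going by the values given here, neither measured step exchanges one halogen for another, so there is no direct precedent in this assay; the only change on that ring, from compound 1 to compound 2, stayed within the scatter. One therefore expects a step of a 1.4-fold lower number from compound 2 to compound 4 (0.14 log units; within the scatter) that remains within the scatter. Compound 4 is estimated at 45000 nM, with a range from 15000 nM to 130000 nM.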

Compound 4, half-maximal inhibitory concentration: > 128000 nM
Compound 4 ended at the assay's limit (the forecaster's own chance of this, stated with the estimate: 15%); middle value at least 2.8-fold (0.45 log units) away from the limit.
By their numbers in this assay, from the lowest: compound 3; then compounds 1 and 2 (each within the scatter of the next). At a limit, above all of these: compound 4.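

In this assay, compound 4 stands at a limit of the assay, not at a number: the limit of > 128000 nM in this assay, at which 1 of the 4 values shown sits. Read as a floor, an at least 2.0-fold higher number from compound 2 to compound 4 (0.30 log units; that floor lies within the scatter) is still within the scatter, so chloro for fluoro at this place is not yet shown to matter, though the true step may be larger. By contrast, an at least 2.9-fold higher number from compound 1 to compound 4 (0.47 log units; beyond the scatter) lies beyond the scatter, so a change on this ring, here of both halogen and place, can now be seen to raise the number.

On these data alone, what bromo or methoxy would give at this place stays open. So does whether ethyl(methyl)amino on the carbonyl carbon would lower the number with 4-chlorobenzyl present.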